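Substitution on the amide nitrogen of compound 1

The source may report more compounds than this note shows. Statements on the series, on what has been measured and on what is new or still open speak of the compounds shown alone.

Working notes on the series. For the measured compounds named here, in a functional assay on HT-29 cells (Homo sapiens) for antiproliferative activity, read by MTT assay, with a stated time of 72 h (on this read-out higher numbers stand for weaker inhibition and lower numbers for stronger inhibition), compound 1 (`C=CC(=O)Nc1nc(-c2ccc(C(F)(F)F)cc2)cs1`) gives 4000 nM, the lower of the two numbers measured so far. Compound 2 (`C=CC(=O)Nc1nc(-c2ccc(OC)cc2)cs1`) gives 12000 nM.

The next structure is compound 3 (`C=CC(=O)N(Cc1cc(C)no1)c1nc(-c2ccc(C(F)(F)F)cc2)cs1`), and its change from compound 1 is (3-methyl-1,2-oxazol-5-yl)methyl in place of hydrogen on an amide-type nitrogen. The added group, (3-methyl-1,2-oxazol-5-yl)methyl, replaces hydrogen on an amide-type nitrogen.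

Going by the values given here, the only measured step is a 3.0-fold higher number from compound 1 to compound 2 (0.48 log units; beyond the scatter). It is modest and beyond the scatter, but it comes from methoxy in place of trifluoromethyl on an aromatic carbon, not from a change on the amide-type nitrogen. It therefore bears on compound 3 only as a rough guide to size. Among the compounds with values here, no measured compound tests substitution at this nitrogen, so the direction is weakly held and the range is wide, reaching past the value of compound 1 on the weaker side.

A modest move towards stronger inhibition in this assay is expected, with the estimated step being a 2.7-fold lower number from compound 1 to compound 3 (0.43 log units; beyond the scatter). For compound 3 the estimated value is 1500 nM, with an expected range of 250 nM to 9000 nM.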

Compound 3, half-maximal inhibitory concentration: 22300 nM
The estimate for compound 3 lay 15-fold (1.17 log units) below the measured number, and the stated range ends below it.
By their numbers in this assay, from the lowest: compound 1; then compounds 2 and 3 (each within the scatter of the next).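

In this assay, for the compounds shown here, this is the first measured change at the amide-type nitrogen, and it points the opposite way from the estimate: a 5.6-fold higher number from compound 1 to compound 3 (0.75 log units; beyond the scatter). Replacing the amide hydrogen of compound 1 with (3-methyl-1,2-oxazol-5-yl)methyl therefore weakens inhibition, so this nitrogen is not a silent position in this assay, and this substituent, with its five-membered aromatic ring, does not improve on the hydrogen. Nothing available explains the loss.

With a single substituent at this nitrogen, the compounds shown leave open whether the step follows from losing the amide hydrogen or from the particular group that enters, a question that a methyl group or a 2-aminoethyl chain at the same nitrogen would help to separate. From the compounds shown here alone, it also remains open whether (3-methyl-1,2-oxazol-5-yl)methyl on the nitrogen of compound 2, which carries methoxy in place of trifluoromethyl, would shift the number in the same direction and by a similar amount.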